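A few compounds are considered here, and "the series" means these few. Any claim that something is new, unique, unknown or untested is made for them only; others in the source may bear on it.

Of the compounds shown here, three built on a shared core have been read in a physicochemical assay for solubility, read by HPLC, at pH 6.8; on this read-out higher numbers stand for higher solubility and lower numbers for lower solubility. Compound 1 `CC(C)(C)c1cc(NC(=O)[C@@H]2CCCCN2Cc2ccc(Cl)cc2)no1` gives < 0.1 ug/mL in this assay, which is a limit of the assay and not a number (the limit of < 0.1 ug/mL in this assay, at which 1 of the 3 values shown sits). Compound 2 `CC(C)CN1CCCC[C@H]1C(=O)Nc1cc(C(C)(C)C)on1` gives 32 ug/mL in this assay. Compound 3 `CC(C)(C)c1cc(NC(=O)[C@@H]2CCCCN2C(=O)C2CCS(=O)(=O)CC2)no1` gives 67 ug/mL in this assay, the highest of the two numbers, with compound 2 lower by a gap beyond the scatter. Compound 4 `CC(C)(C)c1cc(NC(=O)[C@@H]2CCCCN2C(=O)N2CCCCC2)no1` has not been measured; it differs from compound 3 in one place: piperidin-1-yl in place of 1,1-dioxothian-4-yl on a carbonyl carbon. Among the measured compounds shown here, the single measured step, an at least 320-fold higher number from compound 1 to compound 2 (2.50 log units; beyond the scatter), lies on a saturated chain carbon bound to the ring amine nitrogen, not on the carbonyl carbon, so it bears on the new change only as a sign that exchanges of the group on this side of the core can shift solubility widely. Compound 4 is expected to give 10 ug/mL in this assay, within an estimated range from 2 ug/mL to 50 ug/mL. The estimate corresponds to a step of a 6.7-fold lower number from compound 3 to compound 4 (0.83 log units; beyond the scatter), a decrease beyond the scatter.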

Compound 4, solubility: 49 ug/mL
The estimate for compound 4 lay 4.9-fold (0.69 log units) below the measured number; measured number inside the range.
By their numbers in this assay, from the lowest: compounds 2, 4 and 3 (each within the scatter of the next, the first and the last beyond it). At a limit, below all of these: compound 1.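

In this assay, the carbonyl carbon tolerated the exchange of 1,1-dioxothian-4-yl for piperidin-1-yl, the first change read at this place, with a step within the scatter: a 1.4-fold lower number from compound 3 to compound 4 (0.14 log units; within the scatter). On the amine nitrogen in a ring, (piperidin-1-yl)carbonyl in place of isobutyl also stays within the scatter, a 1.5-fold higher number from compound 2 to compound 4 (0.19 log units; within the scatter), whereas the same group in place of 4-chlorobenzyl gives a large step, an at least 490-fold higher number from compound 1 to compound 4 (2.69 log units; beyond the scatter), so that among the four compounds only compound 1 stands apart. That large step starts from compound 1, whose value is a limit of the assay and not a number: the limit of < 0.1 ug/mL in this assay, at which 1 of the 4 values shown sits.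

The compounds shown leave open whether a morpholin-4-yl group, a carboxylic acid or a longer chain on the carbonyl carbon would stay within the scatter of compound 3 and compound 4. From the compounds shown here alone, it also stays open whether a plain benzyl group on the amine nitrogen in a ring would read with compound 1 or with the other three.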